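The source may hold more compounds than are shown below. What is called first, only, known or untested is meant among the compounds shown, and "the series" means these compounds.

Of the compounds shown here, three of one series have been measured in an ADME assay on MT4 cells (Homo sapiens) for cytotoxicity, read by MTT assay, with a stated time of 5 days; a higher number here means that more compound is tolerated, a lower number that less compound is tolerated. Compound 1 `O=c1[nH]c2ccc(Cl)cc2n1S(=O)(=O)Cc1cccc(Cl)c1` gives 152000 nM, and compound 2 `O=c1[nH]c2ccc(Cl)cc2n1S(=O)(=O)Cc1ccc(Cl)cc1` gives 77000 nM. The two differ by 4-chlorophenyl in place of 3-chlorophenyl on a saturated chain carbon bound to a sulfonyl sulfur, and the step is a 2.0-fold lower number from compound 1 to compound 2 (0.30 log units; within the scatter). Compound 3 `O=c1[nH]c2ccc(Cl)cc2n1S(=O)(=O)CCc1cccc(Cl)c1` gives 63000 nM; its number lies close to that of compound 2 and beyond the scatter from that of compound 1. How the core of compound 3 differs from the core of compound 1 is not broken down here.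

Compound 4 `O=c1[nH]c2ccc(Cl)cc2n1S(=O)(=O)CCc1ccc(Cl)cc1` has not yet been measured in this assay. It differs from compound 3 by 4-chlorophenyl in place of 3-chlorophenyl on a saturated chain carbon, two bonds along the chain from a sulfonyl sulfur. This is the same kind of change as that between compound 1 and compound 2, but not the same: there the group sits on a saturated chain carbon bound to a sulfonyl sulfur, here on a saturated chain carbon two bonds along the chain from a sulfonyl sulfur. Among the measured compounds shown here, the only earlier step of this kind was a 2.0-fold lower number from compound 1 to compound 2 (0.30 log units; within the scatter), so an estimated 1.6-fold lower number from compound 3 to compound 4 (0.20 log units; within the scatter) rests on that single step and on the value of compound 3, 63000 nM. Compound 4 is expected to give 40000 nM in this assay, most likely between 20000 nM and 90000 nM.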

Compound 4, half-maximal cytotoxic concentration: 91000 nM
Compound 4: the middle estimate sits 2.3-fold (0.36 log units) below what was measured; measured number outside the range, above it.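

In this assay, 4-chlorophenyl in place of 3-chlorophenyl, on a saturated chain carbon two bonds along the chain from a sulfonyl sulfur, gives a 1.4-fold higher number from compound 3 to compound 4 (0.16 log units; within the scatter). Set beside the earlier step, the same change does not carry over from the core of compound 1 to the core of compound 3 as a step of one size: the same change on two cores in this assay, a 2.0-fold lower number (0.30 log units; within the scatter) from compound 1 to compound 2 and a 1.4-fold higher number (0.16 log units; within the scatter) from compound 3 to compound 4, 2.9-fold (0.46 log units) apart, beyond the scatter of two such steps. Each step on its own lies within the scatter, and only the gap between them goes beyond it, so this single pair of steps shows that the earlier step could not be transferred here, but it does not give a cause or say what the change would do on any further core.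

The compounds shown hold only a chlorophenyl group on these chains, so it remains open how an unsubstituted phenyl, a methoxyphenyl or a pyridine ring would behave, or a longer chain. From the compounds shown here alone, it also remains open whether a third core would follow either of the two steps.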